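Amino for Chloro on a Fused Aryl Urea Core

The compounds below may be only part of what the source reports. "The series", "measured", "known", "first", "only" and "open" are said of these compounds alone.

Compound 1 `Nc1nn(C(=O)Nc2ccc(Cc3ccccc3)cc2)c2ccccc12` — 847 nM
Compound 2 `Nc1nn(C(=O)Nc2ccc(Cc3ccccc3)cc2)c2ccc(Cl)cc12` — 5330 nM

Of the compounds shown here, two have been measured in a functional assay on MDA-MB-231 cells (Homo sapiens) for antiproliferative activity, read by sulforhodamine B assay, with a stated time of 48 h; a higher number here means a weaker inhibitor of growth, a lower number a stronger inhibitor of growth. Compound 1 `Nc1nn(C(=O)Nc2ccc(Cc3ccccc3)cc2)c2ccccc12` gives 847 nM. For the measured compounds named here, compound 2 `Nc1nn(C(=O)Nc2ccc(Cc3ccccc3)cc2)c2ccc(Cl)cc12` gives 5330 nM, and the only step between them, a 6.3-fold higher number from compound 1 to compound 2 (0.80 log units; beyond the scatter), is the sole measured change on this core. Going by the values given here, compound 2 therefore stands at the higher of the two numbers, with compound 1 the only neighbour.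

Compound 3 `Nc1ccc2c(c1)c(N)nn2C(=O)Nc1ccc(Cc2ccccc2)cc1` is the next compound. The change from compound 2 is amino in place of chloro on an aromatic carbon. Among the compounds with values here, no measured step involves an amino group at this position, so the one step that bears on it is a 6.3-fold higher number from compound 1 to compound 2 (0.80 log units; beyond the scatter), which only shows that the chloro substituent carried a modest loss against hydrogen. Whether amino behaves like hydrogen, like chloro, or unlike either cannot be read from the two numbers at hand. The account therefore leans toward a number between the two measured values, with a wide range. Compound 3 is expected at 2200 nM, ranging from 500 nM to 9000 nM. This would be an expected step of a 2.4-fold lower number from compound 2 to compound 3 (0.38 log units; beyond the scatter) in this assay.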

Compound 3, concentration for 50% growth inhibition: 7740 nM
Beside the measured number, compound 3's estimate is 3.5-fold (0.55 log units) below it; the range from low to high includes it.
By their numbers in this assay, from the lowest: compound 1; then compounds 2 and 3 (each within the scatter of the next).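

In this assay the exchange of chloro for amino gives a 1.5-fold higher number from compound 2 to compound 3 (0.16 log units; within the scatter) and so does not separate the two groups at this aromatic carbon, although amino enters with a hydrogen-bond donor and a hydrogen-bond acceptor that chloro does not have. Amino in place of hydrogen gives a 9.1-fold higher number from compound 1 to compound 3 (0.96 log units; beyond the scatter) and thus repeats what chloro showed: the earlier loss against hydrogen no longer rests on one substituent, and among the three compounds only the hydrogen of compound 1 stands apart, with both substituted compounds on the higher side of it. No other measurement here bears on this result or accounts for it.

The three compounds leave open whether any substituent at this carbon can match hydrogen, since a fluoro, methyl, methoxy or hydroxyl group is not among them, and whether an acylated amine such as acetamide would behave as the free amino group does. They also leave open whether the same loss would appear with these groups on the other aromatic carbons of this ring, or with a different group in place of the benzyl on the far aryl ring of the urea.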